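Restoring the 4-methoxy group: compound 4 as a dimethoxy variant

This account rests on a few compounds, and the source may have more. Where it says the series, first, only, none or still open, it means among the compounds named here.

Three compounds share a common core. Compound 1 `COc1ccc(CN2C(=O)C(=O)c3cc(-c4ccc(OC)cc4)ccc32)cc1` gives 50 nM in a functional assay on HepG2 cells (Homo sapiens) for antiproliferative activity, read by MTT assay, with a stated time of 48 h; on this read-out higher numbers stand for weaker inhibition and lower numbers for stronger inhibition. Compound 2 `COc1ccc(-c2ccc3c(c2)C(=O)C(=O)N3Cc2cc(C)cc(C)c2)cc1` gives 410 nM in this assay, and compound 3 `COc1ccc(CN2C(=O)C(=O)c3cc(-c4cccc(OC)c4)ccc32)cc1` gives 1890 nM in this assay. Compound 3 thus has the highest number of the three, standing beyond the scatter from both others; the move from the 4-methoxyphenyl of compound 1 to the 3-methoxyphenyl of compound 3 read as a 38-fold higher number from compound 1 to compound 3 (1.58 log units; beyond the scatter), whereas the change at the benzylic nitrogen substituent read only an 8.2-fold higher number from compound 1 to compound 2 (0.91 log units; beyond the scatter).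

Compound 4 `COc1ccc(CN2C(=O)C(=O)c3cc(-c4ccc(OC)c(OC)c4)ccc32)cc1` differs from compound 3 by methoxy in place of hydrogen on an aromatic carbon. Of the measured steps, only the move from compound 1 to compound 3 bears on this change, and it was large. Compound 4 keeps the 3-methoxy group of compound 3 while regaining the methoxy group of compound 1, so a drop in number, toward but not necessarily reaching compound 1, is expected; the expected step is a 13-fold lower number from compound 3 to compound 4 (1.10 log units; beyond the scatter). Compound 4 is therefore estimated at 150 nM, with a likely range of 40 nM to 600 nM.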

Compound 4, half-maximal inhibitory concentration: > 10000 nM
Compound 4 was reported as a limit; the forecaster's own chance of this, stated with the estimate: 0%; middle value at least 66-fold (1.82 log units) from the limit.
By their numbers in this assay, from the lowest: compound 1; then compound 2; then compound 3. At a limit, above all of these: compound 4.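

In this assay the reading for compound 4 is a limit and not a number: the limit of > 10000 nM in this assay, at which 1 of the 4 values shown sits. Even read against that limit, the second methoxy group raises the number from either side, with an at least 5.2-fold higher number from compound 3 to compound 4 (0.72 log units; beyond the scatter) and an at least 200-fold higher number from compound 1 to compound 4 (2.30 log units; beyond the scatter). Among the compounds shown here, the earlier compounds showed only that the 4-methoxyphenyl of compound 1 and the 3-methoxyphenyl of compound 3 differ, whereas compound 4 shows that the 3,4-dimethoxyphenyl group, which carries both methoxy groups, recovers nothing of compound 1 and stands beyond compound 3.

From the compounds shown here alone, how far compound 4 lies past its limit stays unknown, so both steps give only a lower bound. Going by these compounds, it also stays open whether a hydroxyl group, a fluorine atom or an amine in place of one methoxy group of compound 4 would bring the number back toward compound 1.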